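The source may report more compounds than this note shows. Statements on the series, on what has been measured and on what is new or still open speak of the compounds shown alone.

Compound 3, `CC1=C(/C=C/C(=O)/C=C/c2cccc(F)c2)C(C)(C)CCC1O`, gives 16000 nM in a functional assay on PC-3 cells (Homo sapiens) for cytotoxicity, read by MTT assay, with a stated time of 72 h; a lower number here means a stronger inhibitor, a higher number a weaker inhibitor. Of the three compounds measured it stands second highest; its nearest neighbour is compound 2, `CC1=C(/C=C/C(=O)/C=C/c2ccccc2)C(C)(C)CCC1O`, which gives 15500 nM, and furthest from it is compound 1, `CC1=C(/C=C/C(=O)/C=C/c2ccc(F)cc2)C(C)(C)CCC1`, which gives 25800 nM. Compound 4, `CC1=C(/C=C/C(=O)/C=C/c2ccc(F)cc2)C(C)(C)CCC1O`, differs from compound 3 in one place: 4-fluorophenyl in place of 3-fluorophenyl on a double-bonded chain carbon bound to a double-bonded chain carbon. Within the data shown here, the only measured step that touches the fluorine is a 1.0-fold higher number from compound 2 to compound 3 (0.01 log units; within the scatter), and it stayed within the scatter. Among the measured compounds shown here, compound 1 carries the 4-fluorophenyl of compound 4 but lacks the hydroxyl of compound 3, so no single step links it to compound 4. Swapping 3-fluorophenyl for 4-fluorophenyl is therefore expected to change this assay by no more than the scatter, an expected step of no change at the digits printed from compound 3 to compound 4 (within the scatter). Compound 4 is estimated at 16000 nM, between 8000 nM and 32000 nM.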

Compound 4, half-maximal inhibitory concentration: 6200 nM
Compound 4: middle estimate off by 2.6-fold (0.41 log units), on the high side, outside the stated range (below it).
By their numbers in this assay, from the lowest: compound 4; then compounds 2, 3 and 1 (each within the scatter of the next).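

Moving the fluorine matters in this assay: 4-fluorophenyl in place of 3-fluorophenyl gives a 2.6-fold lower number from compound 3 to compound 4 (0.41 log units; beyond the scatter) even though the two groups hold the same atoms. Fluoro in place of hydrogen on the aromatic carbon likewise gives a 2.5-fold lower number from compound 2 to compound 4 (0.40 log units; beyond the scatter) as 4-fluorophenyl, against a 1.0-fold higher number from compound 2 to compound 3 (0.01 log units; within the scatter) as 3-fluorophenyl. With 4-fluorophenyl present, hydroxy in place of hydrogen on a saturated ring carbon gives a 4.2-fold lower number from compound 1 to compound 4 (0.62 log units; beyond the scatter) in this series.

No measurement shown explains these differences. Going by these compounds, whether a chloro or methoxy group on the aromatic ring would match fluoro remains open.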